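Bromo in place of methyl on compound 3

The source may hold more compounds than are shown below. What is called first, only, known or untested is meant among the compounds shown, and "the series" means these compounds.

Of the compounds shown here, three have numbers so far in a functional assay, read by spectrophotometry, with a stated time of 30 min; a lower number here means a stronger inhibitor, a higher number a weaker inhibitor. In this assay compound 1 `CC(C)(C)c1cc(CCC(=O)NCC2CCN(Cc3ccccc3)CC2)cc(C(C)(C)C)c1O` gives 63400 nM, compound 2 `CC(C)(C)c1cc(/C=C/C(=O)NC2CCN(Cc3ccccc3)CC2)cc(C(C)(C)C)c1O` gives 71900 nM and compound 3 `Cc1ccc(CN2CCC(CCNC(=O)/C=C/c3cc(C(C)(C)C)c(O)c(C(C)(C)C)c3)CC2)cc1` gives 60400 nM. Compound 3 stands within the usual scatter of repeated measurements of both others, so these numbers set no order among the three.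

Compound 4 `CC(C)(C)c1cc(/C=C/C(=O)NCCC2CCN(Cc3ccc(Br)cc3)CC2)cc(C(C)(C)C)c1O` keeps all of compound 3 except one group: its 4-methylbenzyl becomes 4-bromobenzyl, which is bromo in place of methyl on an aromatic carbon. Among the compounds with values here, no pair of measured compounds differs in one place only, so the data do not show directly what this swap does. Within the data shown here, the only guide is how close together the three numbers lie, even though those compounds differ from each other in several places. A step beyond the scatter is therefore not expected in this assay, and no direction can be favoured. For compound 4 the expected value is 58000 nM, with an estimated range from 27000 nM to 120000 nM.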

Compound 4, half-maximal inhibitory concentration: 85600 nM
For compound 4 the middle estimate is 1.5-fold (0.17 log units) below the measured one; low and high end bracket the measured number.
By their numbers in this assay, from the lowest: compounds 3, 1, 2 and 4 (each within the scatter of the next).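

Within the data shown here, compounds 3 and 4 are the first pair here that differ in one place only, so the effect of a single swap can finally be read directly. In this assay, bromo in place of methyl gives a 1.4-fold higher number from compound 3 to compound 4 (0.15 log units; within the scatter), so on this aromatic carbon, para to a large group, the swap does not separate the two compounds. No other measurement bears on this result, so nothing can be said about what lies behind it.

The compounds shown leave open whether a different group on this aromatic carbon, such as an amine, a methoxy or a carboxylic acid, would give a step beyond the scatter. They also leave open whether removing the group altogether, leaving a plain benzyl, would change the reading for this side chain.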